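The compounds below may be only part of what the source reports. "The series", "measured", "known", "first", "only" and "open" are said of these compounds alone.

Working notes on a small set sharing one core, each compound read in a functional assay on K562 cells (Homo sapiens) for cytotoxicity, read by MTT assay, with a stated time of 72 h; a lower number here means a stronger inhibitor, a higher number a weaker inhibitor. Compound 1 `COc1ccc2c(c1)[n+]([O-])nc(NCOC(C)c1ccccc1)[n+]2[O-]` gives 250 nM in this assay. Compound 2 `O=[N+]([O-])c1cccc(COCNc2n[n+]([O-])c3ccccc3[n+]2[O-])c1` gives 650 nM. Compound 3 `COCNc1n[n+]([O-])c2ccccc2[n+]1[O-]` gives 3790 nM, the highest of the three numbers; the nearest of the others is compound 2 and the furthest compound 1, and both gaps lie beyond the scatter. Compound 4 `CCCOCNc1n[n+]([O-])c2ccccc2[n+]1[O-]` is not yet measured and differs from compound 3 by ethyl in place of hydrogen on a saturated chain carbon bound to an oxygen on a saturated carbon. For the measured compounds named here, no two measured compounds differ in only one place, so the step has no measured precedent. Since compounds 1 and 2 both sit well below compound 3, a modest fall in the number is expected, a 2.5-fold lower number from compound 3 to compound 4 (0.40 log units; beyond the scatter). For compound 4 the estimate is 1500 nM, ranging from 500 nM to 4500 nM.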

Compound 4, half-maximal inhibitory concentration: 3890 nM
The estimate for compound 4 lay 2.6-fold (0.41 log units) below the measured number; the measured number falls inside the stated range.
By their numbers in this assay, from the lowest: compound 1; then compound 2; then compounds 3 and 4 (each within the scatter of the next).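

For the compounds shown here, this is the first step that changes one place only: methoxy to propoxy on the shared core gives a 1.0-fold higher number from compound 3 to compound 4 (0.01 log units; within the scatter) in this assay. At this position, ethyl in place of hydrogen leaves the two numbers within the scatter of each other, so this added length alone gives no separation. No outside data bear on this result.

As far as these compounds go, whether a longer chain such as hexyl, or an amine or a carboxylic acid carried on this chain, would separate from compound 3 remains open. Also open, from the compounds shown here alone, is whether the same step holds on a core bearing methoxy.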